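The source may report more compounds than this note shows. Statements on the series, on what has been measured and on what is new or still open speak of the compounds shown alone.

Compound 3 `c1cc2[nH]cc(CCCN3CCNCC3)c2cc1-n1cnnc1` gives 31 nM in an assay on CHO cells for displacement of a labelled ligand from 5-hydroxytryptamine receptor 1D (Homo sapiens) (a lower number here means a stronger inhibitor, a higher number a weaker inhibitor), the highest of the three measured numbers. Compound 1 `c1ccc(CN2CCN(CCCc3c[nH]c4ccc(-n5cnnc5)cc34)CC2)nc1` gives 0.4 nM in this assay, and compound 2 `c1c[nH]c(CN2CCN(CCCc3c[nH]c4ccc(-n5cnnc5)cc34)CC2)n1` gives 1.6 nM in this assay; these two are separated by a 4.0-fold higher number from compound 1 to compound 2 (0.60 log units; beyond the scatter). Compound 4 `CN1CCN(CCCCc2c[nH]c3ccc(-n4cnnc4)cc23)CC1` differs from compound 3 by (4-methylpiperazin-1-yl)methyl in place of piperazin-1-yl on a saturated chain carbon, three bonds along the chain from an aromatic carbon. Within the data shown here, two measured steps bear on this change, both read in the reverse direction: a 78-fold higher number from compound 1 to compound 3 (1.89 log units; beyond the scatter) and a 19-fold higher number from compound 2 to compound 3 (1.29 log units; beyond the scatter) show that the hydrogen on the ring amine nitrogen of compound 3 is a poor substituent in this assay compared with a (pyridin-2-yl)methyl or a (1H-imidazol-2-yl)methyl group. Among the measured compounds shown here, compound 4 places only a methyl on that nitrogen, a smaller group than either, and it also gains one saturated chain carbon, a change for which no measured pair exists, so the extra carbon is uncertain. A lower number than that of compound 3 is nevertheless expected, and the expected step is a 3.9-fold lower number from compound 3 to compound 4 (0.59 log units; beyond the scatter), smaller than the two arylmethyl steps. Compound 4 is estimated at 8 nM in this assay, with a range from 2 nM to 40 nM.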

Compound 4, half-maximal inhibitory concentration: 210 nM
Compound 4: the middle estimate sits 26-fold (1.42 log units) below what was measured; measured number outside the range, above it.
By their numbers in this assay, from the lowest: compound 1; then compound 2; then compound 3; then compound 4.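

Replacing piperazin-1-yl with (4-methylpiperazin-1-yl)methyl on this saturated chain carbon gives a 6.8-fold higher number from compound 3 to compound 4 (0.83 log units; beyond the scatter) in this assay and thus shows that a substituent on the ring amine nitrogen does not by itself bring a lower number. Set against a 78-fold higher number from compound 1 to compound 3 (1.89 log units; beyond the scatter) and a 19-fold higher number from compound 2 to compound 3 (1.29 log units; beyond the scatter), where the compounds carrying an arylmethyl group stand lower than compound 3, this is the first step shown in which the compound with the substituent on that nitrogen stands higher. Nothing measured here accounts for the rise.

Compound 4 differs from compound 3 in two features within one change, the methyl on the ring amine nitrogen and the added saturated chain carbon, so the compounds shown do not tell which of them carries the rise or whether the two act together. Also open, on these data alone, is how a (pyridin-2-yl)methyl or (1H-imidazol-2-yl)methyl group behaves on the longer chain, and whether an ethyl or a benzyl group on that nitrogen, or a shorter chain, would follow compound 4 or instead compound 1 and compound 2.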